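The source may hold more compounds than are shown below. What is called first, only, known or untested is meant among the compounds shown, and "the series" means these compounds.

Of the compounds shown here, three sharing one core have numbers so far in a functional assay on FM3A cells (Mus musculus) for antiproliferative activity, with a stated time of 48 h (a higher number here means a weaker inhibitor, a lower number a stronger inhibitor), and they spread widely. Compound 1 `C=C(Br)C(=O)Nc1ccc(/C=C/C(=O)c2ccc(Cl)cc2)cc1` stands at 1300 nM and compound 3 `Nc1ccc(/C=C/C(=O)c2ccc(Cl)c(Cl)c2)cc1` at 33000 nM while compound 2 `Nc1ccc(/C=C/C(=O)c2ccc(Cl)cc2)cc1` sits at 178000 nM as the highest of the three numbers, which makes it the weakest inhibitor of the group.

Compound 4 `Cc1ccc(C(=O)/C=C/c2ccc(N)cc2)cc1` is still unmeasured. It differs from compound 2 by a single swap: methyl in place of chloro on an aromatic carbon or, in words, methyl in place of chloro on an aromatic carbon. The step of a 140-fold higher number from compound 1 to compound 2 (2.14 log units; beyond the scatter) is large but concerns a group on a nitrogen, so it offers little guidance here. The step of a 5.4-fold lower number from compound 2 to compound 3 (0.73 log units; beyond the scatter) is modest and closer in kind, as it puts chloro in place of hydrogen on an aromatic carbon. Among the measured compounds shown here, no measured compound carries methyl, so the data give no firm direction. In this assay a step of modest size at most is expected, and more likely none beyond the scatter. The expected step is a 1.2-fold lower number from compound 2 to compound 4 (0.07 log units; within the scatter) by this estimate. Expected for compound 4 is 150000 nM with 60000 nM to 350000 nM as the estimated range.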

Compound 4, half-maximal inhibitory concentration: 107000 nM
Compound 4: middle estimate off by 1.4-fold (0.15 log units), on the high side; the range from low to high includes it.
By their numbers in this assay, from the lowest: compound 1; then compound 3; then compounds 4 and 2 (each within the scatter of the next).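

In this assay, putting methyl in place of chloro on this aromatic carbon, para to a large group, gives a 1.7-fold lower number from compound 2 to compound 4 (0.22 log units; within the scatter) and so does not separate the two compounds. The earlier step of a 5.4-fold lower number from compound 2 to compound 3 (0.73 log units; beyond the scatter) showed that adding a second chloro to this ring can shift the number beyond the scatter, whereas this swap shows that the chloro of compound 2 can be exchanged for a methyl without such a shift. Nothing available explains why these two groups give such similar numbers.

Still open, on these data alone, is whether a different group at this position, such as methoxy, an amine or a carboxylic acid, would move the number beyond the scatter. Also open, as far as these compounds go, is whether the swap would behave the same way in compounds carrying the (1-bromoethenyl)carbonyl on the nitrogen, as compound 1 does.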